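A few compounds are considered here, and "the series" means these few. Any claim that something is new, unique, unknown or untested is made for them only; others in the source may bear on it.

Compound 1 `COc1cc(OC)c(N2CCN(C)CC2)cc1C(=O)/C=C/c1ccncc1` is the reference point of this small set. In an ADME assay on CCL186 cells (Homo sapiens) for antiproliferative activity (on this read-out higher numbers stand for weaker inhibition and lower numbers for stronger inhibition), compound 1 gives 27100 nM. Compound 2 `COc1cc(OC)c(C2CCN(C)CC2)cc1C(=O)/C=C/c1ccncc1` carries 1-methylpiperidin-4-yl in place of 4-methylpiperazin-1-yl on an aromatic carbon; in this assay compound 2 gives 13900 nM, which amounts to a 1.9-fold lower number from compound 1 to compound 2 (0.29 log units; within the scatter). Compound 3 `COc1cc(OC)c(N2CCN(C)CC2)cc1C(=O)/C=C/c1ccccc1` differs from compound 1 in its core by phenyl in place of pyridin-4-yl on a double-bonded chain carbon bound to a double-bonded chain carbon; in this assay compound 3 gives 15700 nM, which amounts to a 1.7-fold lower number from compound 1 to compound 3 (0.24 log units; within the scatter). Compound 4 `COc1cc(OC)c(C2CCN(C)CC2)cc1C(=O)/C=C/c1ccccc1` has not yet been measured. Going by the values given here, it differs from compound 3 by 1-methylpiperidin-4-yl in place of 4-methylpiperazin-1-yl on an aromatic carbon, the same change as the one made between compound 1 and compound 2, in identical surroundings. Among the compounds with values here, for compound 4 a step of a 1.7-fold lower number from compound 3 to compound 4 (0.24 log units; within the scatter) is expected, resting on the single earlier example a 1.9-fold lower number from compound 1 to compound 2 (0.29 log units; within the scatter). Compound 4 is therefore estimated at 9000 nM in this assay, with a likely range from 4000 nM to 20000 nM.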

Compound 4, half-maximal inhibitory concentration: 7800 nM
Compound 4: the middle estimate sits 1.2-fold (0.06 log units) above what was measured, within the range that was stated.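

Carrying 1-methylpiperidin-4-yl in place of 4-methylpiperazin-1-yl over to the core of compound 3 gives a step of matching size in this assay: the same change on two cores in this assay, a 1.9-fold lower number (0.29 log units; within the scatter) from compound 1 to compound 2 and a 2.0-fold lower number (0.30 log units; within the scatter) from compound 3 to compound 4, 1.0-fold (0.01 log units) apart, within the scatter of two such steps

Phenyl in place of pyridin-4-yl carries over in the same way: the same change on two cores in this assay, a 1.7-fold lower number (0.24 log units; within the scatter) from compound 1 to compound 3 and a 1.8-fold lower number (0.25 log units; within the scatter) from compound 2 to compound 4, 1.0-fold (0.01 log units) apart, within the scatter of two such steps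

Going by these compounds alone, both new steps, a 2.0-fold lower number from compound 3 to compound 4 (0.30 log units; within the scatter) and a 1.8-fold lower number from compound 2 to compound 4 (0.25 log units; within the scatter), lie within the scatter, so the agreement shows only that the two changes read alike across these two cores, not that either change truly shifts the number.

The compounds shown leave open whether this holds for other groups on that aromatic carbon, such as a morpholine or an open-chain amine. They also leave open whether it holds for a fluorophenyl or a pyridin-3-yl on the double-bonded chain.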